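Working notes on compound 1 and compound 4

A few compounds are considered here, and "the series" means these few. Any claim that something is new, unique, unknown or untested is made for them only; others in the source may bear on it.

The series is followed in an ADME assay on Vero cells (Chlorocebus sabaeus) for cytotoxicity, read by resazurin assay, with a stated time of 72 h; a lower number here means that less compound is tolerated, a higher number that more compound is tolerated. Compound 1 `O=C(/C=C/c1ccc([N+](=O)[O-])o1)c1ccc(C2CCCCC2)cc1` gives only a limit of the assay in this assay, > 100000 nM. Compound 2 `CCCCc1ccc(C(=O)/C=C/c2ccc([N+](=O)[O-])s2)cc1` gives 81300 nM in this assay. For compound 3 `CN(C)c1ccc(/C=C/C(=O)c2ccc(-c3ccccc3)cc2)cc1` this assay records "not determined" (no result reported), so no number is available for it. Going by the values given here, no pair of measured compounds differs in a single place, so no measured step is available; what is known of compound 1 is that it sits at the limit of > 100000 nM in this assay, at which 1 of the 3 values shown sits.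

Compound 4 `O=C(/C=C/c1ccc([N+](=O)[O-])o1)c1ccc(N2CCCCC2)cc1` differs from compound 1 in one place: piperidin-1-yl in place of cyclohexyl on an aromatic carbon. Among the compounds with values here, with no measured step to lean on, the change from compound 1 to compound 4 is expected to be small, within the usual scatter or, if anything, toward a slightly lower value; the expected step is an at least 1.1-fold lower number from compound 1 to compound 4 (0.07 log units; that floor lies within the scatter). Compound 4 is therefore estimated at 85000 nM in this assay, with an expected range of 30000 nM to 200000 nM, and a fair chance that this assay again reports only a limit.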

Compound 4, half-maximal cytotoxic concentration: 349000 nM
Estimate against measurement, compound 4: 4.1-fold (0.61 log units) below; measured number outside the range, above it.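

Going by these compounds alone, no step from compound 1 to compound 4 can be read in this assay. Compound 1 gives only a limit of the assay, > 100000 nM. The compounds shown leave open how large the change is when piperidin-1-yl takes the place of cyclohexyl on an aromatic carbon.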